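The source may report more compounds than this note shows. Statements on the series, on what has been measured and on what is new or still open speak of the compounds shown alone.

Compounds measured in a functional assay for agonist activity at Alpha-1D adrenergic receptor (Homo sapiens); on this read-out lower numbers stand for an effect already at smaller amounts and higher numbers for an effect only at larger amounts of compound:
- compound 1 `COc1ccc(S(C)(=O)=O)c(NCC2=NCCN2)c1`: < 100000 nM
- compound 2 `CSc1c(F)cccc1NCC1=NCCN1`: 33.9 nM
- compound 3 `COc1ccc(SC)c(NCC2=NCCN2)c1`: 5.01 nM

Compound 1 has only a limit in this assay, < 100000 nM, not a number. Of the three, compound 1 is thus the one whose standing on this read-out is not fixed, while compound 2 and compound 3 both have numbers, with compound 3 at 5.01 nM and compound 2 at 33.9 nM; the two differ in more than one place, so their gap is not followed as a single step.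

Compound 4 `CS(=O)(=O)c1ccc(Cl)cc1NCC1=NCCN1` keeps the methylsulfonyl group of compound 1 and differs from it in one place: chloro in place of methoxy on an aromatic carbon. Among the compounds with values here, the only measured step that starts from compound 1 is a step that the limit leaves unreadable from compound 1 to compound 3; it replaces the methylsulfonyl group, not the methoxy, and its size cannot be read because of the limit of < 100000 nM in this assay, at which 1 of the 3 values shown sits. Within the data shown here, no measured step touches a methoxy-to-chloro exchange, so the direction and size of the change into compound 4 rest on the limit alone. The step from compound 1 to compound 4 is expected to be a step that the limit leaves unreadable from compound 1 to compound 4, with no firm direction readable from the data. Compound 4 is estimated at 3000 nM in this assay, within 200 nM to 40000 nM.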

Compound 4, half-maximal effective concentration: < 100000 nM
Compound 4: only a limit was reported (the forecaster's own chance of this, stated with the estimate: 30%); the middle value is on the limit's open side.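

Compound 1 and compound 4 both carry only a limit in this assay, so no step between them can be read: the limit of < 100000 nM in this assay, at which 2 of the 4 values shown sit.

The compounds shown leave open whether chloro in place of methoxy on an aromatic carbon changes this read-out at all, and in which direction.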